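Aryl replacement at the shared core: pyrimidinyl to fluoropyridinyl

The source may report more compounds than this note shows. Statements on the series, on what has been measured and on what is new or still open speak of the compounds shown alone.

Compound 2 `CCN(c1ccc(C#N)c(Cl)c1)c1cc(-c2cncnc2)ccc1C` gives in a functional assay on CWR22R cells (Homo sapiens) for antiproliferative activity, read by CCK-8 assay, with a stated time of 6 days (a lower number here means a stronger inhibitor, a higher number a weaker inhibitor), only a limit, > 30000 nM, and so sits at the limit of this assay (the limit of > 30000 nM in this assay, at which 1 of the 2 values shown sits). Compound 1 `CCN(c1ccc(C#N)c(Cl)c1)c1cc(-c2cnc3ccccc3c2)ccc1C` has no result in this assay, "not determined" (no result reported). Compound 3 `CCN(c1ccc(C#N)c(Cl)c1)c1cc(-c2ccc(F)nc2)ccc1C` differs from compound 2 in one place: 6-fluoropyridin-3-yl in place of pyrimidin-5-yl on an aromatic carbon. Among the measured compounds shown here, no step between two measured compounds is available, so no size of change can be read from the numbers themselves. Compound 3 is expected to gain in this assay by a step beyond the scatter, an at least 3.0-fold lower number from compound 2 to compound 3 (0.47 log units; beyond the scatter), while still counting as a weak inhibitor. The estimate for compound 3 is 10000 nM, within 3000 nM to 30000 nM.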

Compound 3, half-maximal inhibitory concentration: 16500 nM
Compound 3: middle estimate off by 1.7-fold (0.22 log units), on the low side; measured number inside the range.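

In this assay, 6-fluoropyridin-3-yl in place of pyrimidin-5-yl gives this position its first number rather than a limit, with an at least 1.8-fold lower number from compound 2 to compound 3 (0.25 log units; that floor lies within the scatter). Compound 3 gives 16500 nM and remains a weak inhibitor. The value of compound 2 is a limit, so the step is only a floor: the limit of > 30000 nM in this assay, at which 1 of the 3 values shown sits.

Still open, on these data alone, is whether an amine or a carboxylic acid in place of the fluorine would lower the number further. Compound 1 offers no comparison at this position, with "not determined" (no result reported).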